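Swapping Chloro for Hydroxy on a Weakly Active Core

The source may hold more compounds than are shown below. What is called first, only, known or untested is meant among the compounds shown, and "the series" means these compounds.

Within the data shown here, in a functional assay on A549 cells (Homo sapiens) for cytotoxicity, read by MTT assay (on this read-out lower numbers stand for stronger inhibition and higher numbers for weaker inhibition), compound 1 (`C=C1C(=O)[C@]23C[C@@]1(Cl)CC[C@H]2[C@@]12C=CC(=O)[C@](C)(C(=O)O1)[C@H]2[C@@H]3C(=O)OC`) gives 60300 nM, the higher of the two numbers measured so far, which makes it the weaker inhibitor of the pair. Compound 2 (`C=C1C(=O)[C@]23C[C@@]1(Cl)CC[C@H]2[C@@]12C=CC(=O)[C@](C)(C(=O)O1)[C@H]2[C@@H]3C(=O)OCc1ccccc1`) gives 28800 nM. Among the measured compounds shown here, the only measured step is a 2.1-fold lower number from compound 1 to compound 2 (0.32 log units; beyond the scatter), made by putting phenyl in place of hydrogen on a saturated chain carbon bound to an oxygen next to a carbonyl group.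

Compound 3 (`C=C1C(=O)[C@]23C[C@@]1(O)CC[C@H]2[C@@]12C=CC(=O)[C@](C)(C(=O)O1)[C@H]2[C@@H]3C(=O)OC`) leaves that part of compound 1 untouched and changes another place: hydroxy in place of chloro on a saturated ring carbon. In words, this is hydroxy in place of chloro on a saturated ring carbon. For the measured compounds named here, no measured pair tests this swap directly, so the data cannot say which way it will go. Going by the values given here, the one indirect guide is the modest size of a 2.1-fold lower number from compound 1 to compound 2 (0.32 log units; beyond the scatter), a change made elsewhere on the molecule. No step beyond the scatter is therefore expected in this assay, though with real uncertainty in both directions. The estimated step is a 1.0-fold lower number from compound 1 to compound 3 (0.00 log units; within the scatter). For compound 3 the expected value is 60000 nM, with an estimated range from 20000 nM to 150000 nM.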

Compound 3, half-maximal inhibitory concentration: 90900 nM
For compound 3 the middle estimate is 1.5-fold (0.18 log units) below the measured one; the measured number falls inside the stated range.
By their numbers in this assay, from the lowest: compound 2; then compounds 1 and 3 (each within the scatter of the next).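

In this assay, among these compounds, the first change at this saturated ring carbon, hydroxy in place of chloro, gives a 1.5-fold higher number from compound 1 to compound 3 (0.18 log units; within the scatter), so compound 1 and compound 3 cannot be told apart in this assay. The swap replaces a chlorine atom with an oxygen-bearing group and brings a hydrogen-bond donor and a hydrogen-bond acceptor where chloro has neither, yet the step stays within the usual scatter of repeated measurements. No supporting measurement is available to say what lies behind this result.

The two groups tested here cover only a small part of what this ring carbon could carry, so an amine, a methoxy group or plain hydrogen in the same place might still give a step beyond the scatter. Going by these compounds, it is also open whether phenyl in place of hydrogen on the saturated chain carbon bound to an oxygen next to a carbonyl group, the change that gave a 2.1-fold lower number from compound 1 to compound 2 (0.32 log units; beyond the scatter), would give a step of similar size on a core carrying hydroxy instead of chloro.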